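A Furan Takes the Place of the Dimethoxyphenyl

The compounds below may be only part of what the source reports. "The series", "measured", "known", "first", "only" and "open" are said of these compounds alone.

In a functional assay on aorta (strain Wistar) for inhibition, with Thoracic aorta (Rattus norvegicus) as the target (on this read-out higher numbers stand for weaker inhibition and lower numbers for stronger inhibition), compound 3 `CCOc1nc(-c2cc3ccccc3o2)cc(-c2ccc(OC)cc2OC)c1C#N` gives the highest of the three numbers, 488000 nM. Compound 1 `CCOc1nc(-c2cc3ccccc3o2)cc(-c2ccccc2)c1C#N` gives 310000 nM and compound 2 `CCOc1nc(-c2cc3ccccc3o2)cc(-c2ccc(OC)cc2)c1C#N` gives 204000 nM; the step of a 1.6-fold higher number from compound 1 to compound 3 (0.20 log units; within the scatter) stays within the scatter, whereas a 2.4-fold higher number from compound 2 to compound 3 (0.38 log units; beyond the scatter) goes beyond it. Compound 4 `CCOc1nc(-c2cc3ccccc3o2)cc(-c2ccc(C)o2)c1C#N` differs from compound 3 by 5-methylfuran-2-yl in place of 2,4-dimethoxyphenyl on an aromatic carbon. Among the measured compounds shown here, no measured step exchanges one ring for another at that carbon; the two steps that alter the group there, a 1.5-fold lower number from compound 1 to compound 2 (0.18 log units; within the scatter) and a 1.6-fold higher number from compound 1 to compound 3 (0.20 log units; within the scatter), remained within the scatter, so no change beyond the scatter is expected in this assay. The expected step is a 1.6-fold lower number from compound 3 to compound 4 (0.21 log units; within the scatter). Compound 4 is therefore estimated at 300000 nM, with a range from 120000 nM to 800000 nM.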

Compound 4, half-maximal inhibitory concentration: 417000 nM
Estimate against measurement, compound 4: 1.4-fold (0.14 log units) below; low and high end bracket the measured number.
By their numbers in this assay, from the lowest: compounds 2, 1, 4 and 3 (each within the scatter of the next, the first and the last beyond it).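

In this assay the position takes 5-methylfuran-2-yl, a five-membered aromatic ring, in place of 2,4-dimethoxyphenyl (a 1.2-fold lower number from compound 3 to compound 4 (0.07 log units; within the scatter)) or phenyl (a 1.3-fold higher number from compound 1 to compound 4 (0.13 log units; within the scatter)) with no change beyond the scatter. Only the exchange for 4-methoxyphenyl goes beyond it (a 2.0-fold higher number from compound 2 to compound 4 (0.31 log units; beyond the scatter)), so this carbon, opposite the ring nitrogen, has now shown a modest difference between ring types. Nothing available bears on why these numbers fall as they do. Still open, on these data alone, is whether the methyl on the furan counts, and whether an amine or a carboxylic acid at this carbon would move the number further.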